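Working notes on cytotoxicity in an imine series

A few compounds are considered here, and "the series" means these few. Any claim that something is new, unique, unknown or untested is made for them only; others in the source may bear on it.

Measured so far in an ADME assay on Vero cells (Chlorocebus sabaeus) for cytotoxicity, read by MTT assay, with a stated time of 72 h; a higher number here means a weaker inhibitor, a lower number a stronger inhibitor:
- compound 1, `COc1nc(C)nc(/N=C/c2ccc(Br)cc2)n1`, gives > 50 ug/mL
- compound 2, `COc1nc(C)nc(/N=C(\C)c2ccc(C)cc2)n1`, gives > 50 ug/mL
- compound 3, `COc1nc(C)nc(/N=C(\C)c2cc(C)ccc2O)n1`, gives "not determined" (no result reported)

Compound 2 stands at a limit of the assay rather than at a number. Compound 1 also sits at a limit. Among the measured compounds shown here, compound 3 brings nothing to compare, so the only support on the series is the limit of > 50 ug/mL in this assay, at which 2 of the 3 values shown sit, and no step between measured compounds can be drawn.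

Compound 4, `COc1nc(C)nc(/N=C(\C)c2ccc([N+](=O)[O-])cc2)n1`, is not yet measured. Against compound 2 the change is nitro in place of methyl on an aromatic carbon, in words nitro in place of methyl on an aromatic carbon. Nothing measured in the series shows what such a change does in this assay, and with compound 2 at a limit any step could only be seen if compound 4 came back as a number.

The expectation is that compound 4 again gives no number but a limit, so the step from compound 2 to compound 4 is expected to be a step that the limit leaves unreadable from compound 2 to compound 4, that is none beyond the scatter. The estimate for compound 4 is 60 ug/mL, with a range from 25 ug/mL to 200 ug/mL.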

Compound 4, half-maximal inhibitory concentration: > 50 ug/mL
Compound 4 gave a limit, no number; the forecaster's own chance of this, stated with the estimate: 75%; the middle value does not contradict the limit.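

Compound 2 and compound 4 both stand at a limit of this assay, not at a number, so no step can be read for nitro in place of methyl on an aromatic carbon. The compounds shown leave open where any of them would fall as an actual number, and the only support remains this: the limit of > 50 ug/mL in this assay, at which 3 of the 4 values shown sit.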